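The source may hold more compounds than are shown below. What is called first, only, known or untested is meant among the compounds shown, and "the series" means these compounds.

Measured compounds:
compound 1 `CCc1nc(C)c2cnn(CC)c(=O)n12`
compound 2 `CCn1ncc2c(C)nc(C(C)C)n2c1=O`
compound 3 `CCCc1nc(C)c2c(C(C)C)cnc(Nc3cc[nH]n3)n12`

In a functional assay for inhibition, with Homo sapiens as the target (on this read-out higher numbers stand for weaker inhibition and lower numbers for stronger inhibition), compound 1 gives 75600 nM. Compound 2 reaches only the limit of > 48000 nM in this assay. Compound 3 likewise reaches only the limit of > 48000 nM in this assay; the limit of > 48000 nM in this assay, at which 2 of the 3 values shown sit, covers both of them.

The change from compound 2 to compound 1 is hydrogen in place of methyl on a saturated chain carbon bound to an aromatic carbon and a saturated chain carbon, and the step it makes is a step that the limit leaves unreadable from compound 2 to compound 1. The difference between the cores of compound 2 and compound 3 is not broken down here.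

Compound 4 `CCCc1nc(C)c2c(CC)cnc(Nc3cc[nH]n3)n12` carries the same change against compound 3, (hydrogen in place of methyl on a saturated chain carbon bound to an aromatic carbon and a saturated chain carbon), at the same place. Beside the earlier step, the expected step that the limit leaves unreadable from compound 3 to compound 4 is loosely set, because a step that the limit leaves unreadable from compound 2 to compound 1 is unreadable and compound 3 itself sits at the limit of > 48000 nM in this assay, at which 2 of the 3 values shown sit. Compound 4 is therefore expected near 65000 nM in this assay, with an estimated range from 30000 nM to 150000 nM, and a fair chance that only a limit is reported.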

Compound 4, half-maximal inhibitory concentration: > 48000 nM
Compound 4: only a limit was reported; the forecaster's own chance of this, stated with the estimate: 60%; the middle value is on the limit's open side.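

No step can be read from compound 3 to compound 4, since both values are limits: the limit of > 48000 nM in this assay, at which 3 of the 4 values shown sit.
The compounds shown leave open whether isopropyl to ethyl changes inhibition on the core of compound 3, and how far either compound lies past its limit.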